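A hydroxyl returns: from compound 3 to compound 4

This account rests on a few compounds, and the source may have more. Where it says the series, first, only, none or still open, it means among the compounds named here.

Within the data shown here, in a functional assay on MCF7 cells (Homo sapiens) for cytotoxicity, read by MTT assay, with a stated time of 72 h (on this read-out higher numbers stand for weaker inhibition and lower numbers for stronger inhibition), compound 3 `COc1cccc(/C=C2\CCC/C(=C\c3cc(Cl)cc(Cl)c3)C2=O)c1OC` gives 4300 nM, the lowest number so far. Compound 1 `COc1cccc(/C=C2\CCC/C(=C\c3cccc(O)c3)C2=O)c1OC` gives 8800 nM. Compound 2 `COc1cccc(/C=C2\CCC/C(=C\c3cccc(Cl)c3Cl)C2=O)c1OC` gives > 20000 nM, which is a limit of the assay and not a number. Compound 4 `COc1cccc(/C=C2\CCC/C(=C\c3ccc(O)c(Cl)c3)C2=O)c1OC`, not yet measured, carries 3-chloro-4-hydroxyphenyl in place of 3,5-dichlorophenyl (3-chloro-4-hydroxyphenyl in place of 3,5-dichlorophenyl on a double-bonded chain carbon bound to a double-bonded ring carbon). Two measured changes to 3,5-dichlorophenyl bear on this: a 2.0-fold lower number from compound 1 to compound 3 (0.31 log units; beyond the scatter) and an at least 4.6-fold lower number from compound 2 to compound 3 (0.66 log units; beyond the scatter). The first suggests that bringing back a hydroxyl could partly reverse that modest gain, while compound 4 keeps one chlorine. The expected step is small and towards a higher number: a 1.5-fold higher number from compound 3 to compound 4 (0.18 log units; within the scatter). For compound 4 the estimate is 6500 nM, with an expected range of 2500 nM to 17000 nM.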

Compound 4, half-maximal inhibitory concentration: 16400 nM
Compound 4: middle estimate off by 2.5-fold (0.40 log units), on the low side, and the stated range covers the measured number.
By their numbers in this assay, from the lowest: compound 3; then compounds 1 and 4 (each within the scatter of the next). At a limit, above all of these: compound 2.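

In this assay, 3-chloro-4-hydroxyphenyl in place of 3,5-dichlorophenyl weakens inhibition beyond the scatter, with a 3.8-fold higher number from compound 3 to compound 4 (0.58 log units; beyond the scatter), so keeping one chlorine does not preserve the result of compound 3. With 3-chloro-4-hydroxyphenyl in place of 3-hydroxyphenyl, the data show a 1.9-fold higher number from compound 1 to compound 4 (0.27 log units; within the scatter), so these two groups cannot be ordered. With 3-chloro-4-hydroxyphenyl in place of 2,3-dichlorophenyl, the data show an at least 1.2-fold lower number from compound 2 to compound 4 (0.08 log units; that floor lies within the scatter). That comparison cannot be read, as compound 2 sits at a limit: the limit of > 20000 nM in this assay, at which 1 of the 4 values shown sits.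

This swap loses a chlorine and gains a hydroxyl together, and the compounds shown cannot separate the two. From the compounds shown here alone, how an amine in the hydroxyl's place would behave also stays open.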